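Trimming isopropyl to ethyl in compound 2

This account rests on a few compounds, and the source may have more. Where it says the series, first, only, none or still open, it means among the compounds named here.

Compound 1 `N#Cc1cc(C(=O)N2CS(=O)(=O)c3ccccc32)cc(C2CC2)c1O`: 10800 nM
Compound 2 `CC(C)c1cc(C(=O)N2CS(=O)(=O)c3ccccc32)cc(C#N)c1O`: 12500 nM

In an ADME assay on the whole organism (Rattus norvegicus) for pharmacokinetics, read by HPLC, at a dose of 3 mg/kg by the oral route (a higher number here means more compound in the circulation at the dose given, a lower number less compound in the circulation), compound 2 gives 12500 nM, which lies within the scatter of compound 1. Compound 3 `CCc1cc(C(=O)N2CS(=O)(=O)c3ccccc32)cc(C#N)c1O` has hydrogen in place of methyl on a saturated chain carbon bound to an aromatic carbon and a saturated chain carbon, so isopropyl becomes ethyl: hydrogen in place of methyl on a saturated chain carbon bound to an aromatic carbon and a saturated chain carbon. Going by the values given here, only one measured step bears on this, isopropyl in place of cyclopropyl on an aromatic carbon: a 1.2-fold higher number from compound 1 to compound 2 (0.06 log units; within the scatter). One small step is thin evidence, but it gives no reason to expect a real shift. The expected step in this assay is a 1.1-fold lower number from compound 2 to compound 3 (0.06 log units; within the scatter), so none beyond the scatter. Compound 3 is estimated at 11000 nM, with an expected range of 5000 nM to 22000 nM.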

Compound 3, maximal plasma concentration: 12400 nM
The estimate for compound 3 lay 1.1-fold (0.05 log units) below the measured number; the measured number falls inside the stated range.
By their numbers in this assay, from the lowest: compounds 1, 3 and 2 (each within the scatter of the next).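

In this assay the change from isopropyl to ethyl gives a 1.0-fold lower number from compound 2 to compound 3 (0.00 log units; within the scatter) and ethyl in place of cyclopropyl gives a 1.1-fold higher number from compound 1 to compound 3 (0.06 log units; within the scatter) on the same aromatic carbon. Removing a methyl from this group therefore leaves the reading within the scatter, which the earlier isopropyl and cyclopropyl pair could not show. No measurement here gives a cause for this sameness.

The compounds shown cover only these three small carbon groups. They leave open how this reading would respond to a longer chain, an amine or a carboxylic acid at this position.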